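A few compounds are considered here, and "the series" means these few. Any claim that something is new, unique, unknown or untested is made for them only; others in the source may bear on it.

In a functional assay on A549 cells (Homo sapiens) for antiproliferative activity, read by XTT assay, with a stated time of 72 h (on this read-out lower numbers stand for stronger inhibition and higher numbers for weaker inhibition), compound 1 `COc1ccc(-c2cc3ccccc3nc2/C=C/C(=O)c2c(OC)cccc2OC)cc1` gives 7410 nM as its result. Among the compounds with values here, compound 2 `COc1ccc(-c2cc3ccccc3nc2/C=C/C(=O)c2ccc(N)cc2)cc1` gives 7530 nM and so the two values lie within the usual scatter of each other, with compound 1 as the only measured neighbour of compound 2. Compound 3 `COc1ccc(-c2cc3ccccc3nc2/C=C/C(=O)c2ccc(Br)s2)cc1` keeps the shared core and differs from compound 2 at one place, with 5-bromothiophen-2-yl in place of 4-aminophenyl on a carbonyl carbon gives the swap in counts. Within the data shown here, the only measured step at this carbonyl carbon, 4-aminophenyl in place of 2,6-dimethoxyphenyl, was a 1.0-fold higher number from compound 1 to compound 2 (0.01 log units; within the scatter) and so stayed within the scatter. Among the measured compounds shown here, no measured compound carries 5-bromothiophen-2-yl, so this one step is thin evidence, and no change beyond the scatter is expected in this assay here. The expected size is a 1.2-fold lower number from compound 2 to compound 3 (0.06 log units; within the scatter) on this estimate. For compound 3 the estimated value is 6500 nM with an expected range from 2500 nM to 17000 nM as the outcome.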

Compound 3, half-maximal inhibitory concentration: 6250 nM
Compound 3: middle estimate off by 1.0-fold (0.02 log units), on the high side; the measured number falls inside the stated range.
By their numbers in this assay, from the lowest: compounds 3, 1 and 2 (each within the scatter of the next).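

In this assay the 5-bromothiophen-2-yl group gives a 1.2-fold lower number from compound 2 to compound 3 (0.08 log units; within the scatter) and, set against the 2,6-dimethoxyphenyl group, a 1.2-fold lower number from compound 1 to compound 3 (0.07 log units; within the scatter) and both steps lie within the scatter. The position on the carbonyl carbon has now held two six-membered aromatic rings of carbon and one five-membered aromatic ring with a hetero atom, and this last swap also drops the hydrogen-bond donor of 4-aminophenyl, yet the three compounds cannot be told apart on this read-out. Nothing measured here offers an explanation for this sameness.

On these data alone, whether any group on this carbonyl carbon can move the number beyond the scatter stays open, for example a carboxylic acid or a saturated alkyl chain in place of the aromatic ring. The rest of the shared core is identical in all three compounds, so the effect of a change elsewhere is open as well.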